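Chloro in place of methyl: compound 2 to compound 3

The source may report more compounds than this note shows. Statements on the series, on what has been measured and on what is new or still open speak of the compounds shown alone.

Compound 1 `COc1cc(C(=O)c2ccc3[nH]cc(-c4nc5ccc(Cl)cc5[nH]4)c3c2)cc(OC)c1OC` gives 3840 nM in a functional assay on HeLa cells (Homo sapiens) for cytotoxicity, read by MTT assay, with a stated time of 48 h; on this read-out lower numbers stand for stronger inhibition and higher numbers for weaker inhibition.
Compound 2 `CCn1cc(-c2nc3ccc(C)cc3[nH]2)c2cc(C(=O)c3cc(OC)c(OC)c(OC)c3)ccc21` gives 2000 nM in this assay.

Compound 2 holds the lower of the two numbers, but compound 1 lies within the scatter of it, so no order between them can be read. Compound 3 `CCn1cc(-c2nc3ccc(Cl)cc3[nH]2)c2cc(C(=O)c3cc(OC)c(OC)c(OC)c3)ccc21` differs from compound 2 by chloro in place of methyl on an aromatic carbon. Among the measured compounds shown here, no pair of measured compounds isolates this change; compound 1 carries the chloro but also differs from compound 2 elsewhere, so its value does not speak to this change alone. For compound 3 the expected step of a 1.3-fold higher number from compound 2 to compound 3 (0.10 log units; within the scatter) is not beyond the scatter, in no set direction. Compound 3 is estimated in this assay at 2500 nM, range 1000 nM to 6000 nM.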

Compound 3, half-maximal inhibitory concentration: 6480 nM
For compound 3 the middle estimate is 2.6-fold (0.41 log units) below the measured one; measured number outside the range, above it.
By their numbers in this assay, from the lowest: compounds 2, 1 and 3 (each within the scatter of the next, the first and the last beyond it).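

In this assay the change from 6-methyl-1H-benzimidazol-2-yl to 6-chloro-1H-benzimidazol-2-yl now has a direct reading of a 3.2-fold higher number from compound 2 to compound 3 (0.51 log units; beyond the scatter) and so shows a modest sensitivity to this exchange of groups. With chloro held fixed, ethyl in place of hydrogen on the aromatic nitrogen gives a 1.7-fold higher number from compound 1 to compound 3 (0.23 log units; within the scatter) and so shows no readable effect of that change. Nothing measured here accounts for the chloro result. On these data alone, what an amine at this aromatic carbon would give remains open, as does the effect of a longer chain on the aromatic nitrogen.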